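The source may report more compounds than this note shows. Statements on the series, on what has been measured and on what is new or still open speak of the compounds shown alone.

The series shares one core: a saturated chain carbon bound to a carbonyl carbon and a nitrogen on an aromatic ring, with the aryl group on that carbon varied. Compound 1 `Cc1ccc(NC(C(=O)CCc2ccncc2)c2ccccc2C(C)C)c(Cl)c1` carries 2-isopropylphenyl there and gives 3300 nM in an assay on isolated protein for binding affinity to corticotropin-releasing factor receptor 1 (Homo sapiens); a higher number here means a weaker inhibitor, a lower number a stronger inhibitor. Compound 2 `Cc1cccc(C(Nc2ccc(C)cc2Cl)C(=O)CCc2ccncc2)c1` carries 3-methylphenyl. In this assay compound 2 reaches only the limit of the assay, > 10000 nM. Compound 3 `Cc1ccc(NC(C(=O)CCc2ccncc2)c2ccc(Cl)cc2)c(Cl)c1` carries 4-chlorophenyl. In this assay compound 3 also reports only a limit, > 10000 nM, so compound 3 stands at the weak edge of the numbers shown, without a measured value of its own.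

Compound 4 `Cc1ccc(NC(C(=O)CCc2ccncc2)c2ccccc2)c(Cl)c1` differs from compound 3 by hydrogen in place of chloro on an aromatic carbon. The measured steps that bear on it are an at least 3.0-fold higher number from compound 1 to compound 3 (0.48 log units; beyond the scatter) and an at least 3.0-fold higher number from compound 1 to compound 2 (0.48 log units; beyond the scatter), each ending at the limit, and a step that the two limits leave unreadable from compound 2 to compound 3; none of them removes a chloro group alone, and a gap between two limits cannot be sized. The account therefore expects for compound 4 a value near 8000 nM, between 2500 nM and 30000 nM. That expectation means a step of an at least 1.2-fold lower number from compound 3 to compound 4 (0.09 log units; that floor lies within the scatter), read against a limit and so uncertain in size.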

Compound 4, inhibition constant: > 10000 nM
Compound 4 ended at the assay's limit; the forecaster's own chance of this, stated with the estimate: 50%; middle value at least 1.2-fold (0.09 log units) from the limit.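

Taking the chloro group off compound 3 leaves phenyl, and in this assay this change does not bring the compound back within the measurable range: the limit of > 10000 nM in this assay, at which 3 of the 4 values shown sit. The one readable new step is an at least 3.0-fold higher number from compound 1 to compound 4 (0.48 log units; beyond the scatter), so 2-isopropylphenyl, the only aryl group shown with a measured value, now stands apart from phenyl itself as well as from 3-methylphenyl and 4-chlorophenyl. The steps among the three compounds at the limit cannot be read, so chloro, methyl and hydrogen cannot be ranked against one another at this point.

Going by these compounds, how far compound 2, compound 3 and compound 4 lie past the limit stays open. Also open, on these data alone, is whether a methyl, a tert-butyl or a methoxy group in place of the isopropyl group would give a measured value.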